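The source may report more compounds than this note shows. Statements on the series, on what has been measured and on what is new or still open speak of the compounds shown alone.

Measured so far in a functional assay on PC-12 cells (Rattus norvegicus) for cytotoxicity, read by MTT assay, with stated times of 2 h and 24 h, tested at 5 uM; a lower number here means a weaker effect, a higher number a stronger effect of the compound at the concentration tested:
compound 1 `Oc1cc(C(F)(F)F)ccc1-c1nc(-c2ccccc2O)n(-c2ccc(Br)cc2)n1`: 89.8%
compound 2 `Oc1cc(C(F)(F)F)ccc1-c1nc(-c2ccccc2O)n(-c2ccc(I)cc2)n1`: 94.4%
compound 3 `Oc1cc(C(F)(F)F)ccc1-c1nc(-c2ccccc2O)n(-c2cccc(C(F)(F)F)c2)n1`: 92.2%

Compound 1 holds the lowest of the three numbers, but neither neighbour is separated from it by more than the scatter: the gap to compound 3 is a number 2.4 percentage points higher from compound 1 to compound 3 (within the scatter) and the gap to compound 2 is a number 4.6 percentage points higher from compound 1 to compound 2 (within the scatter). Between compound 2 and compound 3 the step is a number 2.2 percentage points lower from compound 2 to compound 3 (within the scatter). All three aryl groups on the aromatic nitrogen of the shared core thus give the same read-out within noise.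

Compound 4 `COc1cccc(-n2nc(-c3ccc(C(F)(F)F)cc3O)nc2-c2ccccc2O)c1` is not yet measured. It differs from compound 1 as follows: 3-methoxyphenyl in place of 4-bromophenyl on an aromatic nitrogen

The relevant precedent is the exchange on the same aromatic nitrogen from compound 1 to compound 3, which moved the number by a number 2.4 percentage points higher from compound 1 to compound 3 (within the scatter); the halogen exchange from compound 1 to compound 2 gave a number 4.6 percentage points higher from compound 1 to compound 2 (within the scatter). Among the measured compounds shown here, no measured compound carries a methoxy group, so the effect of the entering group is untested. On this basis the step from compound 1 to compound 4 is expected to be a number 1.8 percentage points lower from compound 1 to compound 4 (within the scatter), not beyond the scatter. Compound 4 is estimated at 88% in this assay, within the range 76% to 96%.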

Compound 4, a percentage reported as activity, at one concentration (the size of the read-out at that concentration, not a potency): 96.8%
For compound 4 the middle estimate is 8.8 percentage points below the measured one, and the stated range ends below it.
By their numbers in this assay, from the lowest: compounds 1, 3, 2 and 4 (each within the scatter of the next).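

In this assay, 3-methoxyphenyl on the aromatic nitrogen cannot be told apart from the earlier aryl groups: the step is a number 7 percentage points higher from compound 1 to compound 4 (within the scatter) and, for the two other comparisons, a number 2.4 percentage points higher from compound 2 to compound 4 (within the scatter) and a number 4.6 percentage points higher from compound 3 to compound 4 (within the scatter). The earlier compounds shown here carried only halogen or trifluoromethyl on this aryl group, so an oxygen-linked substituent now also falls within the scatter of the series at this position. No measurement on these compounds accounts for this result.

As far as these compounds go, all four compounds keep an aryl group on this nitrogen and share both hydroxyphenyl groups of the core, so the contribution of those hydroxy groups remains open. Also open, from the compounds shown here alone, is how an amine or a carboxylic acid on this aryl group, or a simple alkyl chain in its place, would read in this assay.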